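The source may report more compounds than this note shows. Statements on the series, on what has been measured and on what is new or still open speak of the compounds shown alone.

Working notes on the series. Compound 1 `N=C(N)NCCC[C@H](NC(=O)CN(c1nc(Cl)nc2[nH]cnc12)C1CC1)C(=O)O` and compound 2 `N=C(N)NCCC[C@H](NC(=O)CN(c1nc(Cl)nc2[nH]cnc12)C1CC1)C(=O)OCc1ccccc1` share one core and differ only at the ester position. Going by the values given here, in a functional assay on the whole organism (Tail, strain ICR) with Mus musculus as the target, in the tail flick test, with a stated time of 90 min, at a dose of 25 umol/kg by the oral route (on this read-out higher numbers stand for a stronger effect at the one dose given and lower numbers for a weaker effect), compound 1 gives 27.6%, the lowest of the two numbers so far; compound 2 gives 30.4% in this assay, and the step of a number 2.8 percentage points higher from compound 1 to compound 2 (within the scatter) lies within the scatter. Compound 3 `O=C(O)CNC(=O)CN(c1nc(Cl)nc2[nH]cnc12)C1CC1` is not yet measured. It differs from compound 1 by a hydrogen atom in place of a group of 7 heavy atoms (4 carbon, 3 nitrogen; no ring), on a saturated chain carbon bound to an amide-type nitrogen and a carbonyl carbon, the group leaving from the saturated chain carbon bound to an amide-type nitrogen and a carbonyl carbon. Among the compounds with values here, no measured step touches this position; the one step known, a number 2.8 percentage points higher from compound 1 to compound 2 (within the scatter), concerns the ester oxygen and therefore gives no guide to the size of the present change. With only the value of compound 1 as anchor, a step of a number 7.6 percentage points lower from compound 1 to compound 3 (within the scatter) is expected in this assay for compound 3, with a wide margin. The estimate for compound 3 in this assay is 20%, within 3% to 40%.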

Compound 3, a percentage reported as activity, at one dose (the size of the read-out at that dose, not a potency): 32.3%
Compound 3: the middle estimate sits 12.3 percentage points below what was measured; the measured number falls inside the stated range.
By their numbers in this assay, from the lowest: compounds 1, 2 and 3 (each within the scatter of the next).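

In this assay, a hydrogen atom in place of the group of 7 heavy atoms (4 carbon, 3 nitrogen; no ring), on a saturated chain carbon bound to an amide-type nitrogen and a carbonyl carbon, gives a number 4.7 percentage points higher from compound 1 to compound 3 (within the scatter). Going by these compounds alone, this is the first step at this position, and in this one pair the read-out at the single dose stays within the scatter without that group, so the group is not required for the effect seen here. No available measurement bears on why this large structural change leaves the read-out within the scatter.

Open, as far as these compounds go, is whether a methyl, a primary amine or a longer chain at this carbon would give a step beyond the scatter. Also open, from the compounds shown here alone, is whether a benzyl on the ester oxygen of compound 3 would give a step within the scatter.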